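The source may hold more compounds than are shown below. What is called first, only, known or untested is meant among the compounds shown, and "the series" means these compounds.

Measured compounds in a functional assay on HCT-116 cells (Homo sapiens) for antiproliferative activity, read by MTT assay, with a stated time of 48 h; on this read-out lower numbers stand for stronger inhibition and higher numbers for weaker inhibition:
compound 1 `COc1cc(N(Cc2ccc(C)cc2)C(=O)CSc2nc3ccccc3s2)cc(OC)c1OC` gives > 80000 nM;
compound 2 `COc1ccc(CN(C(=O)CSc2nc3ccccc3s2)c2cc(OC)c(OC)c(OC)c2)cc1O` gives 182 nM;
compound 3 `COc1ccc(CN(C(=O)CSc2nc3ccccc3s2)c2cc(OC)c(OC)c(OC)c2)cc1[N+](=O)[O-]` gives 1280 nM.

The value of compound 1 is only a limit of this assay, not a measured number, and it sits at the limit of > 80000 nM in this assay, at which 1 of the 3 values shown sits. Compound 4 `COc1ccc(CN(C(=O)CSc2nc3ccccc3s2)c2cc(OC)c(OC)c(OC)c2)cc1F` has not yet been measured; it differs from compound 1 by 3-fluoro-4-methoxyphenyl in place of 4-methylphenyl on a saturated chain carbon bound to an amide-type nitrogen.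

Two measured steps start from compound 1 and change the same group on the same place. One is an at least 430-fold lower number from compound 1 to compound 2 (2.64 log units; beyond the scatter), the other at least 62-fold lower number from compound 1 to compound 3 (1.79 log units; beyond the scatter). Both are large and both run in the same direction, toward stronger inhibition. Between the two new groups, a 7.0-fold higher number from compound 2 to compound 3 (0.85 log units; beyond the scatter) shows that the group entering on the aromatic carbon still matters, though by a modest amount compared with the first two steps.

The 3-fluoro-4-methoxyphenyl of compound 4 shares the 4-methoxyphenyl pattern of compounds 2 and 3. A large lowering of the number is therefore expected, an at least 160-fold lower number from compound 1 to compound 4 (2.20 log units; beyond the scatter), landing compound 4 somewhere near compounds 2 and 3. Compound 4 is estimated at 500 nM, in the range 120 nM to 3000 nM.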

Compound 4, half-maximal inhibitory concentration: 1830 nM
Beside the measured number, compound 4's estimate is 3.7-fold (0.56 log units) below it; measured number inside the range.
By their numbers in this assay, from the lowest: compound 2; then compounds 3 and 4 (each within the scatter of the next). At a limit, above all of these: compound 1.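

In this assay, a third replacement of the 4-methylphenyl also gives a large change, an at least 43-fold lower number from compound 1 to compound 4 (1.64 log units; beyond the scatter), so among the compounds shown the large drop does not depend on the hydroxy or the nitro alone. Compound 1 has only a limit of the assay, not a measured number: the limit of > 80000 nM in this assay, at which 1 of the 4 values shown sits. Swapping nitro for fluoro gives no readable difference, a 1.4-fold higher number from compound 3 to compound 4 (0.16 log units; within the scatter), whereas the hydroxy group of compound 2 separates it from the fluoro compound, a 10-fold higher number from compound 2 to compound 4 (1.00 log units; beyond the scatter), leaving compound 2 the most potent of the four.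

From the compounds shown here alone, all three of the more active compounds carry the 4-methoxy group, so its own contribution remains unknown. Going by these compounds, it also remains open how an amine or a carboxylic acid in place of the fluoro would compare with the hydroxy of compound 2.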